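The source may report more compounds than this note shows. Statements on the series, on what has been measured and on what is new or still open speak of the compounds shown alone.

Compound 3 `C=CCn1ncc2ccc(N/C(C)=C3\C(=O)C=C(C)OC3=O)cc21` has been run in an ADME assay on RAW264.7 cells (Mus musculus) for cytotoxicity, read by resazurin assay, with a stated time of 48 h; on this read-out lower numbers stand for higher toxicity in this test and higher numbers for lower toxicity in this test. In this assay compound 3 reaches only the limit, > 100000 nM. Two close relatives sit at the same point. Compound 1 `CC1=CC(=O)/C(=C(/C)Nc2ccc3cnn(C)c3c2)C(=O)O1` carries hydrogen on the saturated chain carbon bound to the aromatic nitrogen. In this assay compound 1 also returns the limit > 100000 nM. Compound 2 `CCn1ncc2ccc(N/C(C)=C3\C(=O)C=C(C)OC3=O)cc21` carries methyl in that place. In this assay compound 2 likewise stops at the limit > 100000 nM. The steps among these three are all unreadable, a step that the two limits leave unreadable from compound 1 to compound 2, a step that the two limits leave unreadable from compound 1 to compound 3 and a step that the two limits leave unreadable from compound 2 to compound 3, since every value stands at the limit of > 100000 nM in this assay, at which 3 of the 3 values shown sit. The next member is compound 4 `CC1=CC(=O)/C(=C(/C)Nc2ccc3cnn(Cc4ccc(C)cc4)c3c2)C(=O)O1`, which differs from compound 3 by 4-methylphenyl in place of vinyl on a saturated chain carbon bound to an aromatic nitrogen. Going by the values given here, no measured step covers this change, and none of the measured steps has a readable size. Among the compounds with values here, the only evidence is that all three values rest at the limit of > 100000 nM in this assay, at which 3 of the 3 values shown sit. The expected step is therefore none beyond the scatter, a number no higher from compound 3 to compound 4 (the limit leaves the size open), with a limit the likeliest outcome again. Compound 4 is estimated at 100000 nM in this assay, within an expected range from 30000 nM to 300000 nM.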

Compound 4, half-maximal cytotoxic concentration: > 100000 nM
Compound 4 ended at the assay's limit; the forecaster's own chance of this, stated with the estimate: 65%; the middle value sits exactly at the limit.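

In this assay no step can be read among compound 1, compound 2, compound 3 and compound 4, since all four values are limits and not numbers: the limit of > 100000 nM in this assay, at which 4 of the 4 values shown sit.

The compounds shown leave open whether any group from hydrogen to 4-methylphenyl, on the saturated chain carbon bound to an aromatic nitrogen, changes toxicity in this test, and by how much.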